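The source may report more compounds than this note shows. Statements on the series, on what has been measured and on what is new or still open speak of the compounds shown alone.

Going by the values given here, in a functional assay on MDA-MB-468 cells (Homo sapiens) for antiproliferative activity, read by sulforhodamine B assay, with a stated time of 72 h (on this read-out lower numbers stand for stronger inhibition and higher numbers for weaker inhibition), compound 3 `COc1ccc2nc(Cl)c(/C=C\c3ccc(C(F)(F)F)cc3)cc2c1` gives 22700 nM, the highest number of the three compounds measured so far and therefore the weakest inhibition among them. Compound 1 `FC(F)(F)c1ccc(/C=C\c2cc3ccccc3nc2Cl)cc1` gives 7380 nM, and compound 2 `Fc1ccc(/C=C\c2cc3ccccc3nc2Cl)cc1` gives 5290 nM.

The next compound to be tested is compound 4 `COc1ccc2nc(Cl)c(/C=C\c3ccc(F)cc3)cc2c1`. It differs from compound 3 by a single change, fluoro in place of trifluoromethyl on an aromatic carbon.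

The same swap has already been measured on the core without the methoxy group, and it gave a 1.4-fold lower number from compound 1 to compound 2 (0.14 log units; within the scatter). That step is too small to separate from the ordinary noise of repeated measurements. Adding the methoxy group mattered more, with a 3.1-fold higher number from compound 1 to compound 3 (0.49 log units; beyond the scatter), so the swap may not carry over exactly to the methoxy series, and the range has to stay fairly wide.

The expected change is a small one toward a lower number, estimated as a 1.4-fold lower number from compound 3 to compound 4 (0.15 log units; within the scatter), with no clear step beyond the scatter. For compound 4 the estimated value is 16000 nM, with an expected range from 8000 nM to 32000 nM.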

Compound 4, half-maximal inhibitory concentration: 15200 nM
For compound 4 the middle estimate is 1.1-fold (0.02 log units) above the measured one, within the range that was stated.
By their numbers in this assay, from the lowest: compounds 2 and 1 (each within the scatter of the next); then compounds 4 and 3 (each within the scatter of the next).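

In this assay, replacing trifluoromethyl with fluoro on the aromatic carbon para to a large group gives a 1.5-fold lower number from compound 3 to compound 4 (0.17 log units; within the scatter), so the swap now also leaves no step beyond the scatter on the methoxy-bearing core, and the two cores agree: the same change on two cores in this assay, a 1.4-fold lower number (0.14 log units; within the scatter) from compound 1 to compound 2 and a 1.5-fold lower number (0.17 log units; within the scatter) from compound 3 to compound 4, 1.1-fold (0.03 log units) apart, within the scatter of two such steps The methoxy group in place of hydrogen now has a second pair to be read on, giving a 2.9-fold higher number from compound 2 to compound 4 (0.46 log units; beyond the scatter), and its step is much the same with fluoro as with trifluoromethyl: the same change on two cores in this assay, a 3.1-fold higher number (0.49 log units; beyond the scatter) from compound 1 to compound 3 and a 2.9-fold higher number (0.46 log units; beyond the scatter) from compound 2 to compound 4, 1.1-fold (0.03 log units) apart, within the scatter of two such steps Across these four compounds, then, the two changes behave independently, with neither step depending on what the other place carries.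

Going by these compounds, whether an amine or a carboxylic acid at the same position would shift the number beyond the scatter remains open. So does what a hydroxyl or a longer ether chain would do in place of the methoxy group.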